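The compounds below may be only part of what the source reports. "The series", "measured", "known", "first", "only" and "open" are said of these compounds alone.

Of the compounds shown here, three sharing one core have been measured in an assay on isolated protein for inhibition of mitogen-activated protein kinase kinase kinase 11 (Homo sapiens), tested at 1 uM; a higher number here means more inhibition at the concentration tested (going by the name of the read-out), a lower number less inhibition. Compound 1 `O=C1NCc2c1c1c(c3[nH]c4ccccc4c23)CCc2cc(O)ccc2-1` gives 0%. Compound 2 `O=C1NCc2c1c1c(c3c2c2ccccc2n3CCO)CCc2cc(OCCO)ccc2-1` gives 46%, the highest of the three numbers; its nearest neighbour is compound 3 `O=C1NCc2c1c1c(c3c2c2ccccc2n3CCO)CCc2cc(OCC3CC3)ccc2-1`, which gives 32%, and its furthest is compound 1. Within the data shown here, the one measured step that changes a single place, a number 14 percentage points lower from compound 2 to compound 3 (beyond the scatter), is the only guide to what a change at that place can do.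

Compound 4 `O=C1NCc2c1c1c(c3c2c2ccccc2n3CCO)CCc2cc(OCc3ccccn3)ccc2-1` differs from compound 2 in the same place: pyridin-2-yl in place of hydroxymethyl on a saturated chain carbon bound to an oxygen on an aromatic ring. Among the measured compounds shown here, no measured step involves a pyridin-2-yl group, so the expectation rests on the one step from compound 2 to compound 3, which was modest and downward. A change of comparable size in the same direction is expected, so the estimated step of a number 11 percentage points lower from compound 2 to compound 4 (beyond the scatter) points to a somewhat lower number. Compound 4 is therefore estimated at 35%, with a plausible range from 15% to 55%.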

Compound 4, a percentage reported as inhibition, at one concentration (the size of the read-out at that concentration, not a potency): 30%
Compound 4: middle estimate off by 5 percentage points, on the high side, and the stated range covers the measured number.
By their numbers in this assay, from the lowest: compound 1; then compounds 4 and 3 (each within the scatter of the next); then compound 2.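

In this assay a second group in place of hydroxymethyl, on a saturated chain carbon bound to an oxygen on an aromatic ring, again gives a drop, a number 16 percentage points lower from compound 2 to compound 4 (beyond the scatter), so the earlier fall no longer rests on cyclopropyl alone. Pyridin-2-yl, a six-membered aromatic ring with one hetero atom, cannot be separated from cyclopropyl here, with a number 2 percentage points lower from compound 3 to compound 4 (within the scatter) and so no order between the two. Among these compounds, nothing measured so far explains why the number falls when hydroxymethyl leaves.

From the compounds shown here alone, whether an amine, a carboxylic acid or a longer chain ending in hydroxyl at this place would match compound 2, at 46% in this assay, stays open. Going by these compounds, compound 1 differs from compound 2 in more than one place, so what each of those changes does alone also stays open.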